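The source may report more compounds than this note shows. Statements on the series, on what has been measured and on what is new or still open speak of the compounds shown alone.

Three compounds share one core and differ only in the aryl group on the amine nitrogen. Compound 1 `Cc1ccc(S(=O)(=O)/N=C(/CCNC2=CC(=O)c3ccccc3C2=O)Nc2ccc(F)cc2)cc1` gives 4260 nM in a functional assay on MCF7 cells (Homo sapiens) for cytotoxicity, read by MTT assay, with a stated time of 48 h; on this read-out lower numbers stand for stronger inhibition and higher numbers for weaker inhibition. Compound 2 `Cc1ccc(S(=O)(=O)/N=C(/CCNC2=CC(=O)c3ccccc3C2=O)Nc2ccccc2[N+](=O)[O-])cc1` gives 3090 nM in this assay, the lowest of the three numbers, though the step between them is a 1.4-fold lower number from compound 1 to compound 2 (0.14 log units; within the scatter), which leaves no order between the two. Compound 3 `Cc1ccc(S(=O)(=O)/N=C(/CCNC2=CC(=O)c3ccccc3C2=O)Nc2cccc(C(F)(F)F)c2)cc1` gives 89100 nM in this assay; the steps of a 21-fold higher number from compound 1 to compound 3 (1.32 log units; beyond the scatter) and a 29-fold higher number from compound 2 to compound 3 (1.46 log units; beyond the scatter) are both clear and large.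

Compound 4 `COc1ccc(N/C(CCNC2=CC(=O)c3ccccc3C2=O)=N\S(=O)(=O)c2ccc(C)cc2)cc1OC` has not yet been measured in this assay. Relative to compound 2 the change is 3,4-dimethoxyphenyl in place of 2-nitrophenyl on an amine nitrogen. Among the measured compounds shown here, no measured step involves the 3,4-dimethoxyphenyl group, so the bearing of the measured steps is indirect: the swap from compound 1 to compound 2 shows that one aryl exchange on this nitrogen can sit within the scatter, while the swap from compound 2 to compound 3 shows that another can lie well beyond it. The dimethoxyphenyl case could therefore fall anywhere between those outcomes, and a moderate weakening is taken as the middle expectation, with a wide range. The step from compound 2 to compound 4 is expected to be a 2.6-fold higher number from compound 2 to compound 4 (0.41 log units; beyond the scatter). Compound 4 is thus estimated at 8000 nM in this assay, within 2000 nM to 40000 nM.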

Compound 4, half-maximal inhibitory concentration: 12300 nM
For compound 4 the middle estimate is 1.5-fold (0.19 log units) below the measured one, within the range that was stated.
By their numbers in this assay, from the lowest: compounds 2 and 1 (each within the scatter of the next); then compound 4; then compound 3.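

In this assay, the 3,4-dimethoxyphenyl group adds an intermediate level on this amine nitrogen: the steps of a 4.0-fold higher number from compound 2 to compound 4 (0.60 log units; beyond the scatter) and a 2.9-fold higher number from compound 1 to compound 4 (0.46 log units; beyond the scatter) set it clearly apart from the 2-nitrophenyl and 4-fluorophenyl pair, while a 7.2-fold lower number from compound 3 to compound 4 (0.86 log units; beyond the scatter) sets it just as clearly apart from the 3-(trifluoromethyl)phenyl case. The earlier compounds shown here showed only a close pair and one far outlier, whereas these four aryl groups now give three separate levels, with compound 2 and compound 1 still sharing the lowest. The 2-nitrophenyl and 3,4-dimethoxyphenyl groups have equal counts of hydrogen-bond donors and acceptors, so those counts do not follow this step, and nothing available explains the differences in value.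

Open, on these data alone, is whether the high number of compound 3 belongs to the trifluoromethyl group itself or to its placement, which a 4-(trifluoromethyl)phenyl group would test. Also open, as far as these compounds go, is how a single methoxy group, a benzyl group or a plain alkyl chain on this nitrogen would read against these four aryl groups.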